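Chloro to cyano, once more on a nitrogen ring

This account rests on a few compounds, and the source may have more. Where it says the series, first, only, none or still open, it means among the compounds named here.

Compound 1 `CCn1c(=O)[nH]c2cccc(Oc3cc(Cl)cc(C#N)c3)c21` and compound 2 `CCn1c(=O)[nH]c2cccc(Oc3cc(C#N)cc(C#N)c3)c21` differ by cyano in place of chloro on an aromatic carbon. In an ADME assay on HEK-293T cells (Homo sapiens) for cytotoxicity, with a stated time of 48 h (a lower number here means that less compound is tolerated, a higher number that more compound is tolerated), compound 1 gives 24100 nM, while compound 2 gives 96600 nM, so a 4.0-fold higher number from compound 1 to compound 2 (0.60 log units; beyond the scatter). Compound 3 `CCn1c(=O)[nH]c2cccc(Oc3ccnc(Cl)c3)c21` carries a different ring at that end of the shared core; the difference between the two cores is not broken down here. In this assay compound 3 gives 95100 nM. Compound 4 `CCn1c(=O)[nH]c2cccc(Oc3ccnc(C#N)c3)c21` is not yet measured and differs from compound 3 by cyano in place of chloro on an aromatic carbon. This is the same kind of change, not the same: the earlier one sits on a six-membered aromatic ring of carbon only, meta to a cyano group, the new one on a six-membered aromatic ring with 1 nitrogen, next to the ring nitrogen. Because the earlier swap gave a 4.0-fold higher number from compound 1 to compound 2 (0.60 log units; beyond the scatter), a step of similar size is expected, a 2.3-fold higher number from compound 3 to compound 4 (0.36 log units; beyond the scatter), though with a wider spread. Compound 4 is estimated at 220000 nM, expected between 80000 nM and 500000 nM.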

Compound 4, half-maximal cytotoxic concentration: > 100000 nM
Compound 4: a limit, no number; the forecaster's own chance of this, stated with the estimate: 35%; the middle value is on the limit's open side.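

In this assay compound 4 gives > 100000 nM, which is a limit of the assay and not a number. The step on this core can therefore be stated only as a floor, an at least 1.0-fold higher number from compound 3 to compound 4 (0.02 log units; that floor lies within the scatter). Set beside the earlier step, this result neither confirms nor rules out that the swap of chloro for cyano carries over from one core to the other: the same change on two cores in this assay, a 4.0-fold higher number (0.60 log units; beyond the scatter) from compound 1 to compound 2 and an at least 1.0-fold higher number (0.02 log units; that floor lies within the scatter) from compound 3 to compound 4; the limit leaves it open whether they differ

The compounds shown leave open how large the step on the second core really is, and so whether it matches the step on the first. They also leave open what other groups in the same place, such as an amine or a carboxylic acid, would give on either core.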